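Urea aryl swap on a pyridinyl-phenyl scaffold against PLK1

The source may report more compounds than this note shows. Statements on the series, on what has been measured and on what is new or still open speak of the compounds shown alone.

Measured compounds:
compound 1, `CCNc1cc(-c2ccc(NC(=O)Nc3c(C)cccc3C)cc2C)ccn1`, 42.1%
compound 2, `CCNc1cc(-c2ccc(NC(=O)Nc3c(C)cccc3C)cc2C(F)(F)F)ccn1`, 59.2%
compound 3, `CCNc1cc(-c2ccc(NC(=O)Nc3ccc(C(F)(F)F)cc3)cc2OC)ccn1`, 40.7%

In an assay on isolated protein for inhibition of serine/threonine-protein kinase PLK1 (Homo sapiens), read by radiometric assay and 33P incorporation, with a stated time of 40 min, tested at 20 uM, in the presence of a further agent that is not named here (on this read-out lower numbers stand for less inhibition and higher numbers for more inhibition at the one concentration tested (going by the name of the read-out)), compound 3 gives the lowest of the three numbers, but its gap to compound 1 is within the scatter, so the two cannot be told apart on these data; only compound 2 lies clearly higher. Among the measured compounds shown here, the one measured step, a number 17.1 percentage points higher from compound 1 to compound 2 (beyond the scatter), concerns the substituent on the central ring and does not touch the urea aryl.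

Compound 4, `CCNc1cc(-c2ccc(NC(=O)Nc3c(C)cccc3C)cc2OC)ccn1`, differs from compound 3 in one place: 2,6-dimethylphenyl in place of 4-(trifluoromethyl)phenyl on an amide-type nitrogen. For the measured compounds named here, no measured pair differs only in this way, so no step speaks directly to the change. What can be drawn on is that compound 1 carries the same 2,6-dimethylphenyl on its urea nitrogen and gives 42.1%, close to the number for compound 3, and that compound 3 itself gives 40.7% in this assay. On that basis the expected step is a number 1.3 percentage points higher from compound 3 to compound 4 (within the scatter), that is, none beyond the scatter. For compound 4 the estimate in this assay is 42%, with a range from 26% to 58%.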

Compound 4, a percentage reported as inhibition, at one concentration (the size of the read-out at that concentration, not a potency): 54.4%
Compound 4: middle estimate off by 12.4 percentage points, on the low side; the measured number falls inside the stated range.
By their numbers in this assay, from the lowest: compounds 3 and 1 (each within the scatter of the next); then compounds 4 and 2 (each within the scatter of the next).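

In this assay, among the compounds shown here, the urea aryl can now be read directly: with methoxy held fixed on the central ring, 2,6-dimethylphenyl in place of 4-(trifluoromethyl)phenyl on an amide-type nitrogen gives a number 13.7 percentage points higher from compound 3 to compound 4 (beyond the scatter), showing that the aryl at this nitrogen affects the read-out, which no earlier pair could isolate. The result also adds a third substituent to the earlier methyl and trifluoromethyl comparison, with 2,6-dimethylphenyl held fixed: methoxy in place of methyl gives a number 12.3 percentage points higher from compound 1 to compound 4 (beyond the scatter) and methoxy in place of trifluoromethyl gives a number 4.8 percentage points lower from compound 2 to compound 4 (within the scatter), so methoxy and trifluoromethyl cannot be told apart here, while the methyl compound stands clearly lower than both. No available evidence bears on the reason for these steps.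

The compounds shown leave open whether the urea aryl swap gives a similar step when the central ring carries methyl or trifluoromethyl instead of methoxy. They also leave open what an amine or a carboxylic acid in place of the methoxy would give in this assay.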